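Biaryl amide series: cytotoxicity across the distal aryl group

The source may hold more compounds than are shown below. What is called first, only, known or untested is meant among the compounds shown, and "the series" means these compounds.

Measured so far, each value being a limit of the assay rather than a number:
compound 1 `CC(=O)c1cccc(-c2ccc(C(=O)N(Cc3cccc(OCCCCCC(=O)O)c3)C(C)C)cc2)c1` in an ADME assay on BJ cells (Homo sapiens) for cytotoxicity, read by CellTiter-Glo and resazurin assay, with a stated time of 72 h (on this read-out higher numbers stand for an effect only at larger amounts of compound and lower numbers for an effect already at smaller amounts), gives > 26000 nM
compound 2 `CC(C)N(Cc1cccc(OCCCCCC(=O)O)c1)C(=O)c1ccc(-c2ccoc2)cc1` in this assay gives > 26000 nM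
compound 3 `CC(C)N(Cc1cccc(OCCCCCC(=O)O)c1)C(=O)c1ccc(-c2cccc(OC(F)(F)F)c2)cc1` in this assay gives > 26000 nM

Compound 1 thus stands only at the limit, as do the other two, since (the limit of > 26000 nM in this assay, at which 3 of the 3 values shown sit). The steps a step that the two limits leave unreadable from compound 1 to compound 2 and a step that the two limits leave unreadable from compound 1 to compound 3 are therefore unreadable in size and direction. Compound 4 `COc1ccc(F)c(-c2ccc(C(=O)N(Cc3cccc(OCCCCCC(=O)O)c3)C(C)C)cc2)c1` differs from compound 1 by 2-fluoro-5-methoxyphenyl in place of 3-acetylphenyl on an aromatic carbon. Among the measured compounds shown here, no measured step bears readably on this change; the three values only show that varying the distal aryl group has so far left every compound at the limit. Compound 4 is expected to give 30000 nM, within 15000 nM to 90000 nM, and most likely again only a limit. The expected step that the limit leaves unreadable from compound 1 to compound 4 is none beyond the scatter.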

Compound 4, half-maximal effective concentration: > 26000 nM
Compound 4 gave a limit, no number; the forecaster's own chance of this, stated with the estimate: 85%; the middle value does not contradict the limit.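

Compound 4 sits at the limit like compound 1, compound 2 and compound 3, so no step among them can be read in size or direction: the limit of > 26000 nM in this assay, at which 4 of the 4 values shown sit.

Still open, on these data alone, is whether any distal aryl group gives a measurable number in this assay.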